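Shifting the chlorine in a semicarbazide-linked quinoline series

A few compounds are considered here, and "the series" means these few. Any claim that something is new, unique, unknown or untested is made for them only; others in the source may bear on it.

Measured compounds:
compound 1 `COc1cc(NC(C)CCCNC(=O)Nc2cccc(Cl)c2)c2ncccc2c1` — 11000 nM
compound 2 `COc1cc(NC(C)CCCNC(=O)NNC(=O)Nc2ccc(Cl)cc2)c2ncccc2c1` — 180 nM

For the measured compounds named here, in a functional assay on MCF7 cells (Homo sapiens) for inhibition, read by MTT assay, with a stated time of 72 h (a lower number here means a stronger inhibitor, a higher number a weaker inhibitor), compound 2 holds the lowest of the two numbers, and the only measured step, a 61-fold lower number from compound 1 to compound 2 (1.79 log units; beyond the scatter), separates it from compound 1. Compound 3 `COc1cc(NC(C)CCCNC(=O)NNC(=O)Nc2cccc(Cl)c2)c2ncccc2c1` differs from compound 2 by 3-chlorophenyl in place of 4-chlorophenyl on an amide-type nitrogen. That measured step altered the linker and the chlorine position together, so it does not isolate the present change; no comparison with the chlorine moved alone exists. A step within the scatter is therefore expected, a 1.4-fold higher number from compound 2 to compound 3 (0.14 log units; within the scatter). Compound 3 is estimated at 250 nM, within 80 nM to 800 nM.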

Compound 3, half-maximal inhibitory concentration: 220 nM
The estimate for compound 3 lay 1.1-fold (0.06 log units) above the measured number; the range from low to high includes it.
By their numbers in this assay, from the lowest: compounds 2 and 3 (each within the scatter of the next); then compound 1.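

In this assay, moving the chlorine alone gives a 1.2-fold higher number from compound 2 to compound 3 (0.09 log units; within the scatter) and so does not separate 3-chlorophenyl from 4-chlorophenyl on this amide-type nitrogen. With the chlorine position held, ((3-chlorophenyl)carbamoyl)amino in place of 3-chlorophenyl gives a 50-fold lower number from compound 1 to compound 3 (1.70 log units; beyond the scatter) and so ties the large difference to that longer linker rather than to the chlorine position. No evidence on the reason for this difference is available.

The compounds shown leave open how an unsubstituted phenyl or a 4-methoxyphenyl would read at this position. They also leave open whether a longer chain in the linker would keep these numbers.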